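Fluoro Gives Way to Nitro in Compound 3

The compounds below may be only part of what the source reports. "The series", "measured", "known", "first", "only" and "open" are said of these compounds alone.

In a functional assay on PC-3 cells (Homo sapiens) for antiproliferative activity, read by MTT assay, with a stated time of 72 h (a lower number here means a stronger inhibitor, a higher number a weaker inhibitor), compound 1 `O=C(N/N=C/c1ccccc1)Nc1ccc(Oc2ccnc3[nH]ccc23)c(F)c1` gives 7940 nM. Compound 2 `O=C(N/N=C/c1ccc(F)cc1)Nc1ccc(Oc2ccnc3[nH]ccc23)c(F)c1`, with fluoro in place of hydrogen on an aromatic carbon, gives 2330 nM, the lower of the two numbers. Compound 3 `O=C(N/N=C/c1ccc([N+](=O)[O-])cc1)Nc1ccc(Oc2ccnc3[nH]ccc23)c(F)c1` keeps the rest of compound 2 but carries nitro in place of fluoro on an aromatic carbon, para to a large group: nitro in place of fluoro on an aromatic carbon. Among the measured compounds shown here, only one measured step bears on this change, and only indirectly: a 3.4-fold lower number from compound 1 to compound 2 (0.53 log units; beyond the scatter), a modest step beyond the scatter. For the measured compounds named here, no compound with nitro has been measured yet, so that step suggests a rough size but no direction. A change of similar size or smaller, in either direction, therefore seems likely in this assay. The expected step is a 1.2-fold lower number from compound 2 to compound 3 (0.07 log units; within the scatter). For compound 3, the estimated value is 2000 nM, with an expected range of 700 nM to 6500 nM.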

Compound 3, half-maximal inhibitory concentration: 150 nM
Compound 3: middle estimate off by 13-fold (1.12 log units), on the high side, and the stated range ends above it.
By their numbers in this assay, from the lowest: compound 3; then compound 2; then compound 1.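

In this assay, the position on the aromatic ring para to a large group turns out to matter far more than the fluoro compound alone could show: nitro in place of fluoro gives a 16-fold lower number from compound 2 to compound 3 (1.19 log units; beyond the scatter), and nitro in place of hydrogen gives a 53-fold lower number from compound 1 to compound 3 (1.72 log units; beyond the scatter). With the rest of the molecule unchanged, a single group at this one position therefore moves the number by a large step, well past the modest change seen with fluoro. Nothing measured here explains why nitro has this effect.

As far as these compounds go, it remains open whether this drop in the number is specific to nitro or is shared by other groups at the same position, such as a nitrile, a trifluoromethyl, a carboxylic acid or an amine. A comparison with the amine would be especially telling, as it also has a nitrogen attached to the ring.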